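Mirror image of compound 3: the step to compound 4

The source may hold more compounds than are shown below. What is called first, only, known or untested is meant among the compounds shown, and "the series" means these compounds.

Three compounds sharing one core have been run in a functional assay on the whole organism with Mus musculus as the target, with stated times of 60 min and 30 min, at a dose of 3 mg/kg by the oral route; on this read-out higher numbers stand for more inhibition at the one dose given (going by the name of the read-out) and lower numbers for less inhibition. Compound 1 `Cc1ccc(F)cc1NC[C@@H]1[C@@H](c2ccc(S(N)(=O)=O)cc2)C1(C)C` gives 0%. Compound 2 `CC1(C)[C@H](CNc2ccc(F)cc2C(F)(F)F)[C@H]1c1ccc(S(N)(=O)=O)cc1` gives 38%. Compound 3 `Cc1cc(F)c(F)cc1NC[C@@H]1[C@@H](c2ccc(S(N)(=O)=O)cc2)C1(C)C` gives 31%. On these numbers compound 3 is second highest of the three, with compound 2 within the scatter of it and compound 1 beyond the scatter below it. Going by the values given here, the only step with a single change is a number 31 percentage points higher from compound 1 to compound 3 (beyond the scatter).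

Compound 4 `Cc1cc(F)c(F)cc1NC[C@H]1[C@H](c2ccc(S(N)(=O)=O)cc2)C1(C)C` keeps every atom and bond of compound 3; the change is the two compounds have the same atoms and bonds and differ only in configuration as drawn: 2 of 2 stereo elements differ (all stereocentres are inverted: mirror images); a stereocentre at a saturated ring carbon is drawn R in compound 3 and S in compound 4; a stereocentre at a saturated ring carbon is drawn R in compound 3 and S in compound 4. Among the compounds with values here, no measured step in this set involves a change of configuration: the one step on record is a change of substituent and says nothing about inverting both ring stereocentres. The direction of the step to compound 4 therefore cannot be read from the measured compounds, and the range must be set wide. The whole span seen so far is open to compound 4: compound 1 gives 0% and compound 3 gives 31%. The estimate for compound 4 in this assay is 12%, from 0% to 35%. The expected step is a number 19 percentage points lower from compound 3 to compound 4 (beyond the scatter).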

Compound 4, a percentage reported as inhibition, in the whole organism at one dose (the size of the read-out at that dose, not a potency): -15%
For compound 4 the middle estimate is 27 percentage points above the measured one; the whole stated range lies above it.
By their numbers in this assay, from the lowest: compound 4; then compound 1; then compounds 3 and 2 (each within the scatter of the next).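

In this assay, configuration at the two saturated ring carbons matters in its own right: the mirror-image pair gives a number 46 percentage points lower from compound 3 to compound 4 (beyond the scatter). The earlier single change concerned only a substituent, fluoro in place of hydrogen on an aromatic carbon, with a number 31 percentage points higher from compound 1 to compound 3 (beyond the scatter); the new step shows that the two fluoro groups and the methyl group of compound 3 do not by themselves secure its read-out, as the same substituents in compound 4 give -15%, a value below zero. The whole of the step from compound 3 to compound 4 can be assigned to the inversion of the two stereocentres, because nothing else in the structure changes: the fact that compounds 3 and 4 differ only in the configuration as drawn

On these data alone, whether one inverted stereocentre alone would carry this step, or both must be inverted together, remains open. Also open, as far as these compounds go, is whether configuration would matter as much with a carboxylic acid in place of the sulfonamide, or in the mirror image of compound 2, which carries a trifluoromethyl group.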